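A few compounds are considered here, and "the series" means these few. Any claim that something is new, unique, unknown or untested is made for them only; others in the source may bear on it.

Measured in a functional assay on SGC-7901 cells (Homo sapiens) for inhibition, read by MTT assay, with a stated time of 24 h; on this read-out higher numbers stand for weaker inhibition and lower numbers for stronger inhibition:
compound 1 `CC1(C)[C@H]2CC[C@]1(C)N(Cc1cn(-c3ccc(Cl)cc3)nn1)C(=O)C2` gives 410 nM
compound 2 `CC1(C)[C@H]2CC[C@]1(C)N(Cc1cn(-c3ccccc3)nn1)C(=O)C2` gives 240 nM
compound 3 `CC1(C)[C@H]2CC[C@]1(C)N(Cc1cn(-c3ccc(F)cc3)nn1)C(=O)C2` gives 500 nM

Compound 3 stands at the highest of the three numbers: against compound 1 the gap is a 1.2-fold higher number from compound 1 to compound 3 (0.09 log units; within the scatter), against compound 2 it is a 2.1-fold higher number from compound 2 to compound 3 (0.32 log units; beyond the scatter). Compound 4 `CC1(C)[C@H]2CC[C@]1(C)N(Cc1cn(-c3cccc(O)c3)nn1)C(=O)C2` is not yet measured; the change from compound 3 is 3-hydroxyphenyl in place of 4-fluorophenyl on an aromatic nitrogen. For the measured compounds named here, the steps that bear on it all vary the group on the phenyl ring: a 1.7-fold lower number from compound 1 to compound 2 (0.23 log units; within the scatter), a 1.2-fold higher number from compound 1 to compound 3 (0.09 log units; within the scatter) and a 2.1-fold higher number from compound 2 to compound 3 (0.32 log units; beyond the scatter). Going by the values given here, all are small, and none involves a 3-hydroxyphenyl, so no precedent fixes the direction. A step in this assay no larger than these is therefore expected; the estimated step is a 1.4-fold lower number from compound 3 to compound 4 (0.15 log units; within the scatter). Compound 4 is estimated at 350 nM, range 120 nM to 1000 nM.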

Compound 4, half-maximal inhibitory concentration: 270 nM
For compound 4 the middle estimate is 1.3-fold (0.11 log units) above the measured one; low and high end bracket the measured number.
By their numbers in this assay, from the lowest: compounds 2, 4, 1 and 3 (each within the scatter of the next, the first and the last beyond it).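

In this assay the 3-hydroxyphenyl group, the first on this ring nitrogen with a hydrogen-bond donor, gives a 1.9-fold lower number from compound 3 to compound 4 (0.27 log units; within the scatter) and a 1.5-fold lower number from compound 1 to compound 4 (0.18 log units; within the scatter) and so is not separated from 4-fluorophenyl or 4-chlorophenyl. Against plain phenyl, hydroxy gives a 1.1-fold higher number from compound 2 to compound 4 (0.05 log units; within the scatter) and is again not separated, so compound 4 lies within the scatter of both compound 2 and compound 3, although those two lie apart by a 2.1-fold higher number from compound 2 to compound 3 (0.32 log units; beyond the scatter) and this position tolerates the hydroxy group in this assay. No measurement on hand gives a reason for these values. From the compounds shown here alone, whether 4-hydroxyphenyl matches 3-hydroxyphenyl remains open, and so does whether an amine or a carboxylic acid on the phenyl ring would move the number beyond the scatter.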